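Pyridine-for-phenyl swap carried onto a second core

The compounds below may be only part of what the source reports. "The series", "measured", "known", "first", "only" and "open" are said of these compounds alone.

Compound 1 `COc1ccc(/C=C/C(=O)c2ccccc2-c2ccc(F)cc2)cc1OC` gives 440 nM in a functional assay on A549 cells (Homo sapiens) for antiproliferative activity, read by sulforhodamine B assay, with a stated time of 48 h; a higher number here means a weaker inhibitor, a lower number a stronger inhibitor. Compound 2 `COc1ccc(/C=C/C(=O)c2ccccc2-c2ccc(F)nc2)cc1OC` differs from it by 6-fluoropyridin-3-yl in place of 4-fluorophenyl on an aromatic carbon and gives 1200 nM in this assay; the step is a 2.7-fold higher number from compound 1 to compound 2 (0.44 log units; beyond the scatter). Compound 3 `O=C(/C=C/c1ccccc1-c1ccc(F)cc1)c1cccc(O)c1` has a different core, and the difference between the two cores is not broken down here. In this assay compound 3 gives 6900 nM, the highest number of the three. Compound 4 `O=C(/C=C/c1ccccc1-c1ccc(F)nc1)c1cccc(O)c1` is not yet measured; it differs from compound 3 by 6-fluoropyridin-3-yl in place of 4-fluorophenyl on an aromatic carbon, the same change as between compound 1 and compound 2, occurring twice among these compounds. One measured instance exists, so the transfer rests on that single step. The expected step is a 2.2-fold higher number from compound 3 to compound 4 (0.34 log units; beyond the scatter), because the measured instance was a 2.7-fold higher number from compound 1 to compound 2 (0.44 log units; beyond the scatter). Compound 4 is therefore estimated at 15000 nM, within 6000 nM to 40000 nM.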

Compound 4, half-maximal inhibitory concentration: 6900 nM
The estimate for compound 4 lay 2.2-fold (0.34 log units) above the measured number; the measured number falls inside the stated range.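

On the core of compound 3, placing 6-fluoropyridin-3-yl in place of 4-fluorophenyl gives no change at the digits printed from compound 3 to compound 4 (within the scatter) in this assay. The rise seen on the core of compound 1 therefore does not carry over to the core of compound 3, and the two steps differ: the same change on two cores in this assay, a 2.7-fold higher number (0.44 log units; beyond the scatter) from compound 1 to compound 2 and no change at the digits printed (within the scatter) from compound 3 to compound 4, 2.7-fold (0.44 log units) apart, beyond the scatter of two such steps

In these two pairs the size of the step depends on the core, but this does not show why, and two pairs give no rule for any further core.

The compounds shown leave open how an amine or a carboxylic acid in place of the fluorine on either ring would behave on each core. Also open, going by these compounds, is which part of the difference between the two cores governs the size of the step.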